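Carbonyl for methylene on the amine nitrogen: compound 3

This account rests on a few compounds, and the source may have more. Where it says the series, first, only, none or still open, it means among the compounds named here.

Compound 1 `C[C@H](NC(=O)[C@H](CCCNC(=N)N)NC(=O)c1ccc(CN(Cc2ccc(F)cc2)Cc2ccccn2)cc1)c1cccc2ccccc12`: 30%
Compound 2 `C[C@H](NC(=O)[C@H](CCCNC(=N)N)NC(=O)c1ccc(CN(Cc2ccncc2)Cc2ccc(F)cc2)cc1)c1cccc2ccccc12`: 16%

Both numbers come from an assay on Jurkat cells for displacement of a labelled ligand from C-X-C chemokine receptor type 4 (Homo sapiens), tested at 10 uM; on this read-out lower numbers stand for less inhibition and higher numbers for more inhibition at the one concentration tested (going by the name of the read-out). Within the data shown here, compound 2 stands lowest of the two, with compound 1 as its only neighbour; the single measured step is a number 14 percentage points lower from compound 1 to compound 2 (beyond the scatter). Compound 3 `C[C@H](NC(=O)[C@H](CCCNC(=N)N)NC(=O)c1ccc(CN(Cc2ccncc2)C(=O)c2ccc(F)cc2)cc1)c1cccc2ccccc12` differs from compound 2 by (4-fluorophenyl)carbonyl in place of 4-fluorobenzyl on an amine nitrogen. Among the measured compounds shown here, that step concerns a change at another site and gives no guide to the present one, so no measured step bears on it. With nothing to go on, compound 3 is expected to stay near compound 2, a number 1 percentage points lower from compound 2 to compound 3 (within the scatter). Compound 3 is estimated at 15%, between 0% and 35%.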

Compound 3, a percentage reported as inhibition, at one concentration (the size of the read-out at that concentration, not a potency): 13%
Beside the measured number, compound 3's estimate is 2 percentage points above it; the measured number falls inside the stated range.
By their numbers in this assay, from the lowest: compounds 3 and 2 (each within the scatter of the next); then compound 1.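

In this assay, the step to (4-fluorophenyl)carbonyl in place of 4-fluorobenzyl on the amine nitrogen is a number 3 percentage points lower from compound 2 to compound 3 (within the scatter) and so shows no readable change at this site, where the earlier step spoke only to the pyridinyl group. With pyridin-4-yl on the same nitrogen, the carbonyl therefore leaves the read-out where it stood. No supporting evidence bears on this step. From the compounds shown here alone, whether the same change holds with the pyridin-2-yl group of compound 1 stays open. So does the effect of a sulfonyl group or a longer chain at this place.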